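The source may report more compounds than this note shows. Statements on the series, on what has been measured and on what is new or still open speak of the compounds shown alone.

In a functional assay on HeLa cells (Homo sapiens) for cytotoxicity, read by MTT assay, with a stated time of 24 h (on this read-out higher numbers stand for weaker inhibition and lower numbers for stronger inhibition), compound 1 `CCCCCCCC(=O)Nc1nnc(S[C@@H]2O[C@H](CO)[C@H](O)[C@H](O)[C@H]2O)s1` gives 50800 nM. This lies within the scatter of both other measured compounds: compound 2 `C=CCCCCCCCCC(=O)Nc1nnc(S[C@@H]2O[C@H](COC(C)=O)[C@H](OC(C)=O)[C@H](OC(C)=O)[C@H]2OC(C)=O)s1` at 77700 nM and compound 3 `CCCCCCCCCCCCCCCC(=O)Nc1nnc(S[C@@H]2O[C@H](COC(C)=O)[C@H](OC(C)=O)[C@H](OC(C)=O)[C@H]2OC(C)=O)s1` at 58300 nM. Compound 4 `C=CCCCCCCCCC(=O)Nc1nnc(S[C@@H]2O[C@H](CO)[C@H](O)[C@H](O)[C@H]2O)s1` differs from compound 1 by allyl in place of hydrogen on a saturated chain carbon, seven bonds along the chain from a carbonyl carbon, with allyl in place of hydrogen on a saturated chain carbon, seven bonds along the chain from a carbonyl carbon. Within the data shown here, the one measured step that alters this chain, a 1.3-fold lower number from compound 2 to compound 3 (0.12 log units; within the scatter), is small, although both of its compounds carry acetyl groups that compound 1 lacks. The expected step is therefore small too, a 1.1-fold higher number from compound 1 to compound 4 (0.03 log units; within the scatter), and nothing beyond the scatter is expected in this assay. Compound 4 is estimated at 55000 nM, with an expected range from 28000 nM to 110000 nM.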

Compound 4, half-maximal inhibitory concentration: 58300 nM
Compound 4: middle estimate off by 1.1-fold (0.03 log units), on the low side; low and high end bracket the measured number.
By their numbers in this assay, from the lowest: compounds 1, 3, 4 and 2 (each within the scatter of the next).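

In this assay the allyl in place of hydrogen, on a saturated chain carbon, seven bonds along the chain from a carbonyl carbon, gives a 1.1-fold higher number from compound 1 to compound 4 (0.06 log units; within the scatter) and so stays within the scatter. The earlier chain step, a 1.3-fold lower number from compound 2 to compound 3 (0.12 log units; within the scatter) and also within the scatter, joined only compounds carrying acetyl groups, whereas this one joins two compounds without them. Nothing given here accounts for this result. As far as these compounds go, whether a chain ending in an amine or a carboxylic acid would also stay within the scatter remains open.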